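Removing one hydroxyl from a hydrazone aryl group

The compounds below may be only part of what the source reports. "The series", "measured", "known", "first", "only" and "open" are said of these compounds alone.

Measured so far:
- compound 1 `CN(C)CCn1cnnc1-c1cc(Oc2ccc(NC(=O)N/N=C/c3c[nH]c4ccccc34)cc2F)ccn1`: 1300 nM
- compound 2 `CN(C)CCn1cnnc1-c1cc(Oc2ccc(NC(=O)N/N=C/c3ccc(O)cc3O)cc2F)ccn1`: 52600 nM

In a functional assay on HT-29 cells (Homo sapiens) for cytotoxicity, read by MTT assay, with a stated time of 72 h (on this read-out lower numbers stand for stronger inhibition and higher numbers for weaker inhibition), compound 2 gives the highest of the two numbers; its nearest neighbour is compound 1, which differs only at the aryl group on the hydrazone carbon, and that exchange produced a 40-fold higher number from compound 1 to compound 2 (1.61 log units; beyond the scatter). Compound 3 `CN(C)CCn1cnnc1-c1cc(Oc2ccc(NC(=O)N/N=C/c3cccc(O)c3)cc2F)ccn1` carries a change at the same place: 3-hydroxyphenyl in place of 2,4-dihydroxyphenyl on a carbon with a double bond to nitrogen. Within the data shown here, no measured step matches this exact exchange, but the one step shows this position can move the number strongly. A moderately lower number is expected, a 3.5-fold lower number from compound 2 to compound 3 (0.54 log units; beyond the scatter), so compound 3 is estimated at 15000 nM, within 3000 nM to 60000 nM.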

Compound 3, half-maximal inhibitory concentration: 330 nM
Beside the measured number, compound 3's estimate is 45-fold (1.66 log units) above it; the whole stated range lies above it.
By their numbers in this assay, from the lowest: compound 3; then compound 1; then compound 2.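

In this assay, taking away one hydroxyl changes the result sharply, with a 160-fold lower number from compound 2 to compound 3 (2.20 log units; beyond the scatter), so the number here depends on more than the presence of a hydroxylated aromatic ring. The 1H-indol-3-yl group is also not needed for a low number, since 3-hydroxyphenyl gives a 3.9-fold lower number from compound 1 to compound 3 (0.60 log units; beyond the scatter). Nothing available explains why the two hydroxyl-bearing groups differ so strongly.

Still open, from the compounds shown here alone, is whether the remaining hydroxyl matters at all, which plain phenyl would test. Methoxy or an amine in its place would show whether another group can serve equally well.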